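Side chain change from compound 3 to compound 4

This account rests on a few compounds, and the source may have more. Where it says the series, first, only, none or still open, it means among the compounds named here.

Values from a functional assay on SGC-7901 cells (Homo sapiens) for cytotoxicity, read by MTT assay, with a stated time of 38 h; on this read-out lower numbers stand for stronger inhibition and higher numbers for weaker inhibition (all compounds measured so far)
- compound 1 (`COc1cc(OC)c2c(=O)c(OCC(=O)N/N=C/c3sccc3C)c(-c3cc(OC)c(OC)c(OC)c3)oc2c1`) gives 10300 nM
- compound 2 (`COc1cc(OC)c2c(=O)c(OCCCCN3CCCC3)c(-c3cc(OC)c(OC)c(OC)c3)oc2c1`) gives 26800 nM
- compound 3 (`COc1cc(OC)c2c(=O)c(OCC(=O)N/N=C/c3ccccc3F)c(-c3cc(OC)c(OC)c(OC)c3)oc2c1`) gives 7720 nM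

Compound 3 sits at the low end of these three numbers. Its nearest neighbour is separated by a 1.3-fold lower number from compound 1 to compound 3 (0.13 log units; within the scatter) and its furthest by a 3.5-fold lower number from compound 2 to compound 3 (0.54 log units; beyond the scatter).

The next compound is compound 4 (`COc1cc(OC)c2c(=O)c(OCCCCN3CCCCC3)c(-c3cc(OC)c(OC)c(OC)c3)oc2c1`). The change is a group of 9 heavy atoms (8 carbon, 1 nitrogen; one six-membered non-aromatic ring with 1 hetero atom) in place of a group of 12 heavy atoms (8 carbon, 2 nitrogen, 1 oxygen, 1 fluorine; one six-membered aromatic ring of carbon only), on a saturated chain carbon bound to an oxygen on an aromatic ring. The entering group is 3-(piperidin-1-yl)propyl, on a saturated chain carbon bound to an oxygen on an aromatic ring.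

For the measured compounds named here, compound 2 is the only measured compound with a non-aromatic ring carrying 1 hetero atom at this place, so it is the closest guide. Read in reverse, a 3.5-fold lower number from compound 2 to compound 3 (0.54 log units; beyond the scatter) is the most relevant step, and a 2.6-fold higher number from compound 1 to compound 2 (0.42 log units; beyond the scatter) points the same way. The aromatic ring exchange in a 1.3-fold lower number from compound 1 to compound 3 (0.13 log units; within the scatter) gives a similar starting level from either compound. Going by the values given here, no measured compound carries the six-membered non-aromatic ring, so the effect of ring size remains unknown.

A modest rise in the number is expected in this assay, with the estimated step being a 2.8-fold higher number from compound 3 to compound 4 (0.45 log units; beyond the scatter) and probably beyond the scatter. The estimate for compound 4 is 22000 nM (expected range 10000 nM to 48000 nM).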

Compound 4, half-maximal inhibitory concentration: 6080 nM
For compound 4 the middle estimate is 3.6-fold (0.56 log units) above the measured one, and the stated range ends above it.
By their numbers in this assay, from the lowest: compounds 4, 3 and 1 (each within the scatter of the next); then compound 2.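

In this assay, for the compounds shown here, the exchange of pyrrolidin-1-yl for piperidin-1-yl gives the first comparison of ring size on this chain, and with a 4.4-fold lower number from compound 2 to compound 4 (0.64 log units; beyond the scatter), the size of the ring on the side chain clearly counts at this position. Going by these compounds alone, the non-aromatic ring alone therefore does not carry the higher number seen for compound 2: with a 1.3-fold lower number from compound 3 to compound 4 (0.10 log units; within the scatter) and a 1.7-fold lower number from compound 1 to compound 4 (0.23 log units; within the scatter), 3-(piperidin-1-yl)propyl cannot be told apart from the side chains ending in an aromatic ring, and compound 2 is the one compound that goes against this level among the four. No supporting data are available to explain this difference between the two rings.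

Within the data shown here, with only two ring sizes on this chain, it remains open whether the level seen for compound 4 would hold for a seven-membered azepan-1-yl ring, a morpholin-4-yl ring or an open-chain diethylamino group. The compounds shown also leave open how a shorter or longer chain carrying piperidin-1-yl would read, and whether the gap between the two rings would persist at another chain length.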